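Triazole series on a bromophenol core: cytotoxicity notes

The source may report more compounds than this note shows. Statements on the series, on what has been measured and on what is new or still open speak of the compounds shown alone.

Three compounds sharing one core have been run in a functional assay on A549 cells (Homo sapiens) for cytotoxicity, read by MTT assay, with a stated time of 4 days; on this read-out lower numbers stand for stronger inhibition and higher numbers for weaker inhibition. Compound 1 `C=C1C[C@]23C[C@@]1(O)CC[C@H]2c1cc(Br)c(O)c(C)c1[C@@H]3Cn1cc(-c2ccc(OC)cc2)nn1` carries a 4-methoxyphenyl on the triazole. In this assay compound 1 gives > 20000 nM, which is a limit of the assay and not a number. Compound 2 `C=C1C[C@]23C[C@@]1(O)CC[C@H]2c1cc(Br)c(O)c(C)c1[C@@H]3Cn1cc(-c2ccc(F)cc2)nn1` carries a 4-fluorophenyl instead, and in this assay compound 2 gives 17900 nM. Compound 3 `C=C1C[C@]23C[C@@]1(O)CC[C@H]2c1ccc(O)c(C)c1[C@@H]3Cn1cc(-c2ccc(F)cc2)nn1` keeps the 4-fluorophenyl of compound 2 but differs in the core: hydrogen in place of bromo on an aromatic carbon. In this assay compound 3 gives > 20000 nM, again a limit of the assay rather than a number.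

Two steps are counted. The change methoxy in place of fluoro on an aromatic carbon gives an at least 1.1-fold higher number from compound 2 to compound 1 (0.04 log units; that floor lies within the scatter). The core change gives an at least 1.1-fold higher number from compound 2 to compound 3 (0.04 log units; that floor lies within the scatter). Both steps are bounded by the limit of > 20000 nM in this assay, at which 2 of the 3 values shown sit, so neither can be sized beyond its floor.

Compound 4 `C=C1C[C@]23C[C@@]1(O)CC[C@H]2c1ccc(O)c(C)c1[C@@H]3Cn1cc(-c2ccc(OC)cc2)nn1` is not yet measured. It stands to compound 3 as compound 1 stands to compound 2: methoxy in place of fluoro on an aromatic carbon. The two place descriptions read the same word for word, so this is the same change as before, set on the core of compound 3 rather than that of compound 2, the core difference being the one already given.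

The step from compound 3 to compound 4 is expected to be a step that the limit leaves unreadable from compound 3 to compound 4, resting on an at least 1.1-fold higher number from compound 2 to compound 1 (0.04 log units; that floor lies within the scatter), which left the number at the floor. Compound 3 already reports a limit, > 20000 nM, so a number for compound 4 is not expected either. Compound 4 is expected at 30000 nM, within 15000 nM to 80000 nM, and most likely returned only as a limit.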

Compound 4, half-maximal inhibitory concentration: > 20000 nM
Compound 4: a limit, no number; the forecaster's own chance of this, stated with the estimate: 85%; the middle value is on the limit's open side.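

Compound 4 returns a limit and not a number, so neither the step from compound 3 to compound 4 nor the step from compound 1 to compound 4 can be read: the limit of > 20000 nM in this assay, at which 3 of the 4 values shown sit.

The compounds shown leave open how large the change from 4-fluorophenyl to 4-methoxyphenyl or the change from bromo to hydrogen is, with compound 2 the only one of the four giving a number.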